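Swapping the furan for an aminopyridine on the thiazole core

The compounds below may be only part of what the source reports. "The series", "measured", "known", "first", "only" and "open" are said of these compounds alone.

Measured compounds:
compound 1 `O=C(O)Cc1sc(C(Cc2ccccc2)c2ccccc2)nc1-c1ccc(Cl)cc1`, 56 nM
compound 2 `CS(=O)(=O)Nc1cccc(-c2nc(C(c3ccc(F)cc3)c3ccc(F)cc3)sc2CC(=O)O)c1`, 40 nM
compound 3 `O=C(O)Cc1sc(C(c2ccc(F)cc2)c2ccc(F)cc2)nc1-c1ccoc1`, 14 nM

In an in vitro assay on HEK385-7 cells for displacement of a labelled ligand from prostaglandin D2 receptor 2 (Homo sapiens) (a higher number here means a weaker inhibitor, a lower number a stronger inhibitor), compound 3 gives the lowest of the three numbers. Compound 4 `O=C(O)Cc1sc(C(c2ccc(F)cc2)c2ccc(F)cc2)nc1-c1ccnc(N2CCCC2)c1` differs from compound 3 by 2-(pyrrolidin-1-yl)pyridin-4-yl in place of furan-3-yl on an aromatic carbon. Going by the values given here, the only measured step at this same place is a 2.9-fold lower number from compound 2 to compound 3 (0.46 log units; beyond the scatter), where a six-membered aromatic ring gave way to a five-membered one and the number fell. Going back from furan-3-yl to a six-membered aromatic ring in compound 4 might therefore undo part of that gain, but no measured step covers the 2-(pyrrolidin-1-yl)pyridin-4-yl group itself, so the expectation is loose. Compound 4 is expected to show a modest rise, a 2.1-fold higher number from compound 3 to compound 4 (0.33 log units; beyond the scatter), giving an estimated 30 nM with a range from 10 nM to 90 nM.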

Compound 4, half-maximal inhibitory concentration: 230 nM
The estimate for compound 4 lay 7.7-fold (0.88 log units) below the measured number; the whole stated range lies below it.
By their numbers in this assay, from the lowest: compound 3; then compounds 2 and 1 (each within the scatter of the next); then compound 4.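

In this assay this position proves sensitive to the group it carries: there is a 16-fold higher number from compound 3 to compound 4 (1.22 log units; beyond the scatter) when 2-(pyrrolidin-1-yl)pyridin-4-yl replaces furan-3-yl. There is also a 5.8-fold higher number from compound 2 to compound 4 (0.76 log units; beyond the scatter) when the same group replaces 3-(methanesulfonamido)phenyl, so having a six-membered aromatic ring here does not alone set the number. No measurement shown explains this loss.

Still open, going by these compounds, is whether the loss follows the pyrrolidine ring or the pyridine ring. A plain pyridin-4-yl group, or a dimethylamino group on the pyridine, would help separate the two.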